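Swapping the six-position substituent of an adenosine-like inhibitor

The source may report more compounds than this note shows. Statements on the series, on what has been measured and on what is new or still open speak of the compounds shown alone.

Of the compounds shown here, three have been tested in an assay on isolated protein for binding affinity to Equilibrative nucleoside transporter 1 (Homo sapiens); a lower number here means a stronger inhibitor, a higher number a weaker inhibitor. Compound 1 `O=[N+]([O-])c1ccc2c(c1)CCN(c1ncnc3c1ncn3[C@@H]1O[C@H](CO)[C@@H](O)[C@H]1O)C2` gives 182 nM, and compound 2 `O=[N+]([O-])c1ccc2c(c1)CN(c1ncnc3c1ncn3[C@@H]1O[C@H](CO)[C@@H](O)[C@H]1O)CC2` gives 5.5 nM. Compound 3 `OC[C@H]1O[C@@H](n2cnc3c(NCc4ccco4)ncnc32)[C@H](O)[C@@H]1O` gives 36300 nM, the highest of the three numbers: its value lies a long way above that of compound 1 and further still above that of compound 2, and both gaps are well beyond the usual scatter.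

The next step starts from compound 3 and leads to compound 4 `CCSc1ncnc2c1ncn2[C@@H]1O[C@H](CO)[C@@H](O)[C@H]1O`, which has not yet been tested. The change is ethylsulfanyl in place of ((furan-2-yl)methyl)amino on an aromatic carbon. Compound 4 carries a small chain where compound 3 carries a ring-bearing group, and the measured compounds give no direct guide for such a swap, only the general picture that the six-position substituent matters greatly.

The expectation is a moderate move to a lower number, with wide uncertainty, so that the step of a 4.5-fold lower number from compound 3 to compound 4 (0.66 log units; beyond the scatter) is an estimate rather than a firm prediction. Compound 4 is expected to give 8000 nM in this assay, within a range from 1500 nM to 40000 nM.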

Compound 4, half-maximal inhibitory concentration: 57500 nM
Compound 4: middle estimate off by 7.2-fold (0.86 log units), on the low side; measured number outside the range, above it.
By their numbers in this assay, from the lowest: compound 2; then compound 1; then compounds 3 and 4 (each within the scatter of the next).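

In this assay this swap gives a 1.6-fold higher number from compound 3 to compound 4 (0.20 log units; within the scatter), so at this aromatic carbon ethylsulfanyl and ((furan-2-yl)methyl)amino cannot be told apart. The group that leaves has a five-membered aromatic ring and a hydrogen-bond donor, while the group that enters has neither, and this difference leaves no measurable mark on the number. Nothing available here explains this result.

From the compounds shown here alone, it remains open whether ethylamino, which would combine the nitrogen link of compound 3 with a short chain like that of compound 4, would read differently. A benzylsulfanyl group would show whether a ring on the sulfur link changes the number.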